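This account rests on a few compounds, and the source may have more. Where it says the series, first, only, none or still open, it means among the compounds named here.

Working notes on the series, read in a functional assay on HCT-116 cells (Homo sapiens) for antiproliferative activity, read by MTT assay, with a stated time of 72 h; on this read-out lower numbers stand for stronger inhibition and higher numbers for weaker inhibition. Compound 1 `NC1=NC2(CCSCC2)N(OCCCOc2ccc(Cl)c(Cl)c2)C(N)=N1` gives 1 nM, and compound 3 `CC(C)(C)c1ccc(OCCCON2C(N)=NC(N)=NC23CCSCC3)cc1` gives 1 nM. Compound 2 `NC1=NC2(CCOCC2)N(OCCCOc2ccccc2)C(N)=N1` stands at 6010 nM, the highest number of the three and beyond the scatter from both others. Compound 4 `COc1ccc(OCCCON2C(N)=NC(N)=NC23CCOCC3)cc1` departs from compound 2 by one change: methoxy in place of hydrogen on an aromatic carbon, para to a large group. For the measured compounds named here, no measured pair isolates a single change. Compound 3, at 1 nM, has a substituted phenyl but also differs from compound 2 in the core, so it supports only a partial shift in expectation. The expected step is a 7.5-fold lower number from compound 2 to compound 4 (0.88 log units; beyond the scatter), toward a lower number and beyond the scatter. For compound 4 the estimated value is 800 nM, with an expected range of 50 nM to 6000 nM.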

Compound 4, half-maximal inhibitory concentration: 1500 nM
The estimate for compound 4 lay 1.9-fold (0.27 log units) below the measured number; measured number inside the range.
By their numbers in this assay, from the lowest: compounds 1 and 3 (each within the scatter of the next); then compound 4; then compound 2.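

In this assay, for the compounds shown here, the change from phenyl to 4-methoxyphenyl gives a 4.0-fold lower number from compound 2 to compound 4 (0.60 log units; beyond the scatter) and is the first single change that can be read. It shows that, on the core of compound 2, this position para to a large group responds to methoxy, though only modestly. No measurement available here accounts for the step.

As far as these compounds go, whether an amine or a carboxylic acid at this position would give a larger step remains open. So does whether methoxy would have any comparable effect on the core of compound 1.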